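This account rests on a few compounds, and the source may have more. Where it says the series, first, only, none or still open, it means among the compounds named here.

Measured compounds in an assay on isolated protein for binding affinity to corticotropin-releasing factor receptor 1 (Rattus norvegicus); on this read-out lower numbers stand for stronger inhibition and higher numbers for weaker inhibition:
Compound 1 `Cc1cc(C)c2c(C#N)cn(-c3ccc(C(C)C)cc3Br)c2n1` gives 363 nM.
Compound 3 `Cc1cc(Cl)c2c(C#N)cn(-c3ccc(C(C)C)cc3Br)c2n1` gives 722 nM.
Compound 2 `Cc1cc(O)nc2c1c(C#N)cn2-c1ccc(C(C)C)cc1Br` reaches only the limit > 10000 nM, which is a limit of this assay and not a number.

Compound 1 and compound 3 are not separated beyond the scatter: a 2.0-fold higher number from compound 1 to compound 3 (0.30 log units; within the scatter). Compound 2 sits at the limit of > 10000 nM in this assay, at which 1 of the 3 values shown sits, the single large effect seen so far: an at least 27-fold higher number from compound 1 to compound 2 (1.44 log units; beyond the scatter).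

Compound 4 `Cc1cc(C)c2c(C(N)=O)cn(-c3ccc(C(C)C)cc3Br)c2n1` differs from compound 1 by carbamoyl in place of cyano on an aromatic carbon. Neither measured step touches this position; both change the group on the six-membered ring of the shared core, so they give no direct guide. For the measured compounds named here, the only exchange that replaced a carbon substituent by a donor-bearing group, from compound 1 to compound 2, lost binding beyond the scatter, and the exchange to chloro stayed within it. For compound 4 a moderate loss is therefore expected, a 4.1-fold higher number from compound 1 to compound 4 (0.62 log units; beyond the scatter), with wide uncertainty. The estimate for compound 4 in this assay is 1500 nM, expected to fall between 400 nM and 6000 nM.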

Compound 4, inhibition constant: > 10000 nM
Compound 4 gave a limit, no number; the forecaster's own chance of this, stated with the estimate: 15%; middle value at least 6.6-fold (0.82 log units) away from the limit.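

The earlier compounds shown here all carry cyano on this aromatic carbon of the five-membered ring, so they gave no reading of this place. In this assay, carbamoyl in place of cyano gives an at least 27-fold higher number from compound 1 to compound 4 (1.44 log units; beyond the scatter) and so shows that this position does not accept every small group, although the exchange adds only one heavy atom and one hydrogen-bond donor. Compound 4 stands at a limit of the assay and not at a number, so the full size of the loss stays unread: the limit of > 10000 nM in this assay, at which 2 of the 4 values shown sit.

Whether any replacement of cyano keeps binding remains open, as the compounds shown carry only cyano and carbamoyl here. A methyl, an aminomethyl or a carboxylic acid on this carbon would help separate the loss of the nitrile from the arrival of the amide hydrogen.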